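The compounds below may be only part of what the source reports. "The series", "measured", "known", "first", "only" and "open" are said of these compounds alone.

Compounds with measurements in an ADME assay on Vero cells (Chlorocebus sabaeus) for cytotoxicity, read by MTT assay, with a stated time of 72 h; on this read-out lower numbers stand for stronger inhibition and higher numbers for weaker inhibition:

Compound 1, `COc1ccccc1C1CC(c2cc3ccccc3o2)=NN1C(=O)c1ccncc1`: in this assay compound 1 gives > 202000 nM, which is a limit of the assay and not a number.
Compound 2, `O=C(O)c1ccccc1C1CC(c2cc3ccccc3o2)=NN1C(=O)c1ccncc1`: in this assay compound 2 gives > 170000 nM, again a limit.
Compound 3, `O=C(c1ccncc1)N1N=C(c2cc3ccccc3o2)CC1c1ccc(O)cc1`: in this assay compound 3 gives > 200000 nM, also a limit.

Compound 3 therefore stands on a limit, and the two further values around it are limits as well, so no one of the three can be set above or below another. The steps between them are unreadable: a step that the two limits leave unreadable from compound 1 to compound 2, a step that the two limits leave unreadable from compound 1 to compound 3 and a step that the two limits leave unreadable from compound 2 to compound 3.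

The new compound is compound 4, `O=C(c1ccncc1)N1N=C(c2cc3ccccc3o2)CC1c1ccco1`. It differs from compound 3 by furan-2-yl in place of 4-hydroxyphenyl on a saturated ring carbon. Going by the values given here, the only measured steps that touch this position on the shared core are the ones into compound 3, and both left no readable size, so there is no measured basis for a direction in this assay. All three measured compounds sit at limits, and a change of the group on the saturated ring carbon gave no readable movement among them.

The step is expected to be a number no higher from compound 3 to compound 4 (the limit leaves the size open). Compound 4 is estimated at 200000 nM, between 100000 nM and 400000 nM, most likely again reported as a limit.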

Compound 4, half-maximal inhibitory concentration: > 208000 nM
Compound 4: a limit, no number (the forecaster's own chance of this, stated with the estimate: 85%); middle value at least 1.0-fold (0.01 log units) away from the limit.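

In this assay compound 4 gives > 208000 nM, a limit of the assay and not a number. Going by these compounds alone, with compound 1, compound 2 and compound 3 also at limits, no step to compound 4 can be read. The compounds shown leave open the concentration at which any of them would inhibit these cells by half, and whether the group on the saturated ring carbon changes it.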